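This account rests on a few compounds, and the source may have more. Where it says the series, first, only, none or still open, it means among the compounds named here.

Compound 2 `CC[C@@H]1C(=O)N(C)c2cnc(-n3ccc4cc(C(=O)NC5CCCC5)ccc43)nc2N1C1CCCC1` and compound 1 `CC[C@@H]1C(=O)N(C)c2cnc(-n3ccc4cc(C(N)=O)ccc43)nc2N1C1CCCC1` share one core; compound 3 `CCC1C(=O)N(C)c2cnc(-n3ccc4cc(C(=O)NC5CCCC5)ccc43)nc2N1c1ccn(C)n1` and compound 4 `CCC1C(=O)N(C)c2cnc(-n3ccc4cc(C(N)=O)ccc43)nc2N1c1ccn(C)n1` share another. The difference between the two cores is not broken down here. In a functional assay on HeLa cells (Homo sapiens) for antiproliferative activity, read by CCK-8 assay, with a stated time of 72 h (on this read-out lower numbers stand for stronger inhibition of growth and higher numbers for weaker inhibition of growth), compound 2 gives 247 nM and compound 1 gives 674 nM. What separates them is hydrogen in place of cyclopentyl on an amide-type nitrogen, and that change made a 2.7-fold higher number from compound 2 to compound 1 (0.44 log units; beyond the scatter). Compound 3, tested in this assay, gives 27400 nM, far weaker than either compound 1 or compound 2. Compound 4 has not yet been tested in this assay. It differs from compound 3 by hydrogen in place of cyclopentyl on an amide-type nitrogen, the same change as between compound 2 and compound 1, at a place described in identical terms. Whether the second core responds in the same way cannot be checked within these four compounds, so the expectation rests on one earlier step only. With that single instance as the guide, the expected step is a 2.4-fold higher number from compound 3 to compound 4 (0.38 log units; beyond the scatter). This rests on compound 1 against compound 2, where the change gave a 2.7-fold higher number from compound 2 to compound 1 (0.44 log units; beyond the scatter). Compound 4 is therefore expected to give about 65000 nM in this assay, most likely between 30000 nM and 150000 nM.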

Compound 4, concentration for 50% growth inhibition: 27400 nM
The estimate for compound 4 lay 2.4-fold (0.38 log units) above the measured number, outside the stated range (below it).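

In this assay, putting hydrogen in place of cyclopentyl on the amide-type nitrogen of the core of compound 3 gave no change at the digits printed from compound 3 to compound 4 (within the scatter). The same change therefore did not carry over with the same size from one core to the other, so a step seen on one core was a poor guide to the step on the other: the same change on two cores in this assay, a 2.7-fold higher number (0.44 log units; beyond the scatter) from compound 2 to compound 1 and no change at the digits printed (within the scatter) from compound 3 to compound 4, 2.7-fold (0.44 log units) apart, beyond the scatter of two such steps. This comparison rests on a single pair on each core, so it shows that the core can matter for this change, but it gives no general rule for the series and does not say which feature of the two cores lies behind the gap.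

The compounds shown leave open how a methyl group or a longer chain on that amide-type nitrogen would behave on each core. They also leave open whether a carboxylic acid in place of the carbamoyl group would give steps that match or differ between the two cores.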